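Extending the Alkynyl Chain on a Cytosine-Type Nucleoside

The compounds below may be only part of what the source reports. "The series", "measured", "known", "first", "only" and "open" are said of these compounds alone.

In a functional assay on L1210 cells (Mus musculus) for cytotoxicity, with a stated time of 48 h (on this read-out lower numbers stand for stronger inhibition and higher numbers for weaker inhibition), compound 1, `CCCC#Cc1cn([C@@H]2O[C@H](CO)[C@@H](O)[C@H](O)[C@H]2O)c(=O)[nH]c1=O`, gives 115000 nM. Compound 2, `CCCC#Cc1cn([C@@H]2O[C@H](CO)[C@@H](O)[C@H](O)[C@H]2O)c(=O)nc1N`, reaches only the limit of this assay, and compound 2 gives >= 250000 nM. Compound 2 thus stands at a limit rather than at a number, so its distance from compound 1 cannot be measured on the values shown. Compound 3, `CCCCCC#Cc1cn([C@@H]2O[C@H](CO)[C@@H](O)[C@H](O)[C@H]2O)c(=O)nc1N`, has not yet been tested in this assay. It differs from compound 2 by ethyl in place of hydrogen on a saturated chain carbon, three bonds along the chain from a triple-bonded carbon. Among the measured compounds shown here, no measured step covers a change of this kind, so any expectation rests on compound 2 alone, which sits at the limit of >= 250000 nM in this assay, at which 1 of the 2 values shown sits. The change is expected to move the read-out little, with no direction beyond the scatter, as an at least 1.2-fold lower number from compound 2 to compound 3 (0.09 log units; that floor lies within the scatter). Compound 3 is therefore estimated at 200000 nM, within a range from 60000 nM to 600000 nM, with a fair chance that this assay again reports only a limit.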

Compound 3, half-maximal inhibitory concentration: >= 250000 nM
Compound 3: a limit, no number; the forecaster's own chance of this, stated with the estimate: 60%; middle value at least 1.2-fold (0.09 log units) away from the limit.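

Compound 3 gives only a limit, >= 250000 nM, in this assay, and compound 2 stands at a limit too, so no step from compound 2 to compound 3 can be read: the limit of >= 250000 nM in this assay, at which 2 of the 3 values shown sit.

The compounds shown leave open whether ethyl in place of hydrogen on this chain changes the read-out at all.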